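This account rests on a few compounds, and the source may have more. Where it says the series, first, only, none or still open, it means among the compounds named here.

Of the compounds shown here, three of a shared core have been measured in an assay on isolated protein for inhibition of DNA topoisomerase 1 (Homo sapiens), tested at 100 uM; a lower number here means a weaker effect, a higher number a stronger effect of the compound at the concentration tested. Compound 1 `COc1ccc(/C=C/C(=O)c2ccco2)cc1Br` gives 92%. Compound 2 `COc1cc(O)ccc1/C=C/C(=O)c1ccc(NC(C)=O)cc1` gives 100%, a number eight points above that of compound 1, which is within the scatter, so the two cannot be told apart. Compound 3 `O=C(/C=C/c1ccc(N2CCCC2)cc1)c1ccc(O)cc1` gives 74.7%, which lies beyond the scatter below compound 1. On these numbers compound 1 thus stands second of three, with one neighbour indistinguishable from it and one clearly weaker.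

Compound 4 `COc1ccc(/C=C/C(=O)c2cccs2)cc1Br` has not yet been measured. It differs from compound 1 in one place only: thiophen-2-yl in place of furan-2-yl on a carbonyl carbon. The rest of the molecule, including the bromine and the methoxy group on the other ring, is unchanged. For the measured compounds named here, no measured pair in this small set shows what such a swap does, so the expectation rests on the closeness of compound 4 to compound 1. The step expected in this assay is small, a number 4 percentage points lower from compound 1 to compound 4 (within the scatter), not beyond the scatter in either direction. Compound 4 is therefore estimated at 88%, with a range from 70% to 100%.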

Compound 4, a percentage reported as inhibition, at one concentration (the size of the read-out at that concentration, not a potency): 74.4%
Compound 4: the middle estimate sits 13.6 percentage points above what was measured; the range from low to high includes it.
By their numbers in this assay, from the lowest: compounds 4 and 3 (each within the scatter of the next); then compounds 1 and 2 (each within the scatter of the next).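

In this assay, for the compounds shown here, thiophen-2-yl in place of furan-2-yl on a carbonyl carbon gives a number 17.6 percentage points lower from compound 1 to compound 4 (beyond the scatter) in the first pair of this set that differs in one place only. The two groups match in heavy atom count, ring size, donors and acceptors, and differ in the hetero atom, oxygen against sulfur, so this place on the core responds to a swap that leaves those counts unchanged. Nothing at hand explains the lower number for the sulfur ring.

Going by these compounds, it remains open whether the same swap would give a similar step on a core without the bromine and the methoxy group. The compounds shown also leave open how a pyrrol-2-yl ring, with nitrogen as its hetero atom, would read on this carbonyl carbon.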